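The source may hold more compounds than are shown below. What is called first, only, known or untested is meant among the compounds shown, and "the series" means these compounds.

Compound 1 `Nc1nc(Nc2ccc(S(N)(=O)=O)cc2)sc1C(=O)c1ccccc1[N+](=O)[O-]` gives 9000 nM
Compound 2 `Nc1nc(Nc2ccc(S(N)(=O)=O)cc2)sc1C(=O)c1cccc(F)c1` gives 3900 nM

Both numbers come from a functional assay on GC-2 cells (Mus musculus) for cytotoxicity, read by MTT assay, with a stated time of 72 h (a lower number here means a stronger inhibitor, a higher number a weaker inhibitor), and compound 2 holds the lower one, which makes it the stronger inhibitor of this pair. Compound 3 `Nc1nc(Nc2ccc(S(N)(=O)=O)cc2)sc1C(=O)c1cccc([N+](=O)[O-])c1` keeps the shared core but carries nitro in place of fluoro on an aromatic carbon so that 3-fluorophenyl becomes 3-nitrophenyl.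

For the measured compounds named here, only one measured step bears on this change, and only indirectly. It is a 2.3-fold lower number from compound 1 to compound 2 (0.36 log units; beyond the scatter) and it is modest, though beyond the usual scatter. Going by the values given here, that step changes the group and its place together, so no measured pair compares fluoro with nitro at the same place. Among the compounds with values here, compound 1, the only measured compound with a nitro group, gives 9000 nM and this suggests a small move towards a higher number, which may not clear the scatter. The expected change is a 1.3-fold higher number from compound 2 to compound 3 (0.12 log units; within the scatter) and its direction is uncertain. Compound 3 is estimated at 5200 nM (range 2000 nM to 13000 nM) in this assay once it is measured.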

Compound 3, half-maximal inhibitory concentration: 20000 nM
Estimate against measurement, compound 3: 3.8-fold (0.59 log units) below; measured number outside the range, above it.
By their numbers in this assay, from the lowest: compound 2; then compound 1; then compound 3.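

In this assay, for the compounds shown here, nitro in place of fluoro on the same aromatic carbon gives a 5.1-fold higher number from compound 2 to compound 3 (0.71 log units; beyond the scatter), the first direct comparison of these two groups at one place. Keeping the nitro group and changing only where it sits, 3-nitrophenyl in place of 2-nitrophenyl gives a 2.2-fold higher number from compound 1 to compound 3 (0.35 log units; beyond the scatter), so the number depends on the position of the nitro group as well as on the identity of the group. Among these three compounds, compound 2, with its 3-fluorophenyl group, therefore holds the lowest number, and neither nitro compound reaches it, wherever the nitro group sits.

Nothing in the data shown explains why either change moves the number in this way.

The compounds shown leave open whether fluoro also responds to a change of place, since it appears at only one place here. They also leave open how an amine or a methyl group would compare with fluoro and nitro on the same aromatic carbon, so three compounds cannot yet show a general trend at this position.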